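Removing a chloro from a diaryl urea series

A few compounds are considered here, and "the series" means these few. Any claim that something is new, unique, unknown or untested is made for them only; others in the source may bear on it.

The shared core of compound 1 `COc1cc(Cl)cc(-c2nn(-c3cccc(NC(=O)Nc4ccc(Cl)c(C(F)(F)F)c4)c3)cc2-c2ccncc2)c1` carries a urea whose distal ring bears a chloro and a trifluoromethyl group. In a functional assay on SK-MEL-28 cells (Homo sapiens) for inhibition, read by sulforhodamine B assay, with a stated time of 48 h, tested at 0.01 uM (on this read-out lower numbers stand for a stronger effect and higher numbers for a weaker effect at the one concentration tested), compound 1 gives 98%. Compound 2 `COc1cc(Cl)cc(-c2nn(-c3cccc(NC(=O)Nc4cc(C(F)(F)F)cc(C(F)(F)F)c4)c3)cc2-c2ccncc2)c1`, with two trifluoromethyl groups on that ring, gives 103% in this assay, and compound 3 `COc1cc(Cl)cc(-c2nn(-c3cccc(NC(=O)Nc4ccc(Cl)c(Cl)c4)c3)cc2-c2ccncc2)c1`, with two chloro groups, gives 101%. Compound 1 thus has the lowest of the three numbers, but its gaps to compound 3 and to compound 2 both lie within the scatter, so nothing separates the three. Among the measured compounds shown here, the one step recorded between single-point neighbours, chloro in place of trifluoromethyl on an aromatic carbon, gave a number 3 percentage points higher from compound 1 to compound 3 (within the scatter). Compound 4 `COc1cc(Cl)cc(-c2nn(-c3cccc(NC(=O)Nc4cccc(C(F)(F)F)c4)c3)cc2-c2ccncc2)c1` differs from compound 1 by hydrogen in place of chloro on an aromatic carbon. The step from compound 1 to compound 3 is the nearest guide, and it moved nothing beyond the scatter, so for compound 4 he expects a step of about a number 2 percentage points higher from compound 1 to compound 4 (within the scatter) in this assay, no change beyond the scatter. His estimate for compound 4 in this assay is 100%, with a range from 92% to 108%.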

Compound 4, a percentage reported as activity, at one concentration (the size of the read-out at that concentration, not a potency): 99%
For compound 4 the middle estimate is 1 percentage points above the measured one; the range from low to high includes it.
By their numbers in this assay, from the lowest: compounds 1, 4, 3 and 2 (each within the scatter of the next).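

Among the compounds shown here, replacing the chloro on the aromatic carbon ortho to a trifluoromethyl group and para to a large group with hydrogen, which turns 4-chloro-3-(trifluoromethyl)phenyl into 3-(trifluoromethyl)phenyl, gave a number 1 percentage points higher from compound 1 to compound 4 (within the scatter) in this assay, so this chloro can be removed altogether without a change beyond the scatter, whereas the earlier compounds showed only one substituent exchanged for another. The other two comparisons agree: the change to the single trifluoromethyl ring gave a number 2 percentage points lower from compound 3 to compound 4 (within the scatter), and hydrogen in place of trifluoromethyl gave a number 4 percentage points lower from compound 2 to compound 4 (within the scatter), so a distal ring with one substituent is not separated from the rings with two. Nothing available explains why these changes leave the number within the scatter.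

Going by these compounds, it remains open whether an amine or a carboxylic acid on this same aromatic carbon would move the number beyond the scatter. Also open, on these data alone, is whether compound 1 and compound 4 would separate at any concentration other than the single one tested here.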